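Imidazole substitution pattern and muscarinic binding

A few compounds are considered here, and "the series" means these few. Any claim that something is new, unique, unknown or untested is made for them only; others in the source may bear on it.

Compound 3 `CC(C)c1nccn1CCC(C(N)=O)(c1ccccc1)c1ccccc1` gives 1.8 nM in an assay on ileum with muscarinic acetylcholine receptor M3 (Cavia porcellus) as the target (on this read-out lower numbers stand for stronger inhibition and higher numbers for weaker inhibition), the lowest number of the three measured: compound 2 `CCc1nccn1CCC(C(N)=O)(c1ccccc1)c1ccccc1` gives 78.1 nM and compound 1 `c1ccc(C(CCn2ccnc2)c2ccccc2)cc1` gives 89.1 nM. For the measured compounds named here, the one measured step with a single change is a 43-fold lower number from compound 2 to compound 3 (1.64 log units; beyond the scatter), showing that the branching of the group on the imidazole matters greatly. Compound 4 `Cc1ncn(CCC(C(N)=O)(c2ccccc2)c2ccccc2)c1C` differs from compound 3 by 4,5-dimethyl-1H-imidazol-1-yl in place of 2-isopropyl-1H-imidazol-1-yl on a saturated chain carbon, three bonds along the chain from two aromatic carbons and a carbonyl carbon. Going by the values given here, no measured pair tests moving substituents off that ring carbon, so the direction is uncertain, but because the large gain in a 43-fold lower number from compound 2 to compound 3 (1.64 log units; beyond the scatter) came from the group now removed, a weaker result is expected. For compound 4 the estimate is 30 nM, with a likely range from 5 nM to 180 nM, an expected step of a 17-fold higher number from compound 3 to compound 4 (1.22 log units; beyond the scatter).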

Compound 4, antagonist equilibrium constant: 2.7 nM
Estimate against measurement, compound 4: 11-fold (1.05 log units) above; measured number outside the range, below it.
By their numbers in this assay, from the lowest: compounds 3 and 4 (each within the scatter of the next); then compounds 2 and 1 (each within the scatter of the next).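

In this assay, 4,5-dimethyl-1H-imidazol-1-yl in place of 2-isopropyl-1H-imidazol-1-yl gives a 1.5-fold higher number from compound 3 to compound 4 (0.18 log units; within the scatter) so a low number at this position does not depend on the isopropyl group. In place of 2-ethyl-1H-imidazol-1-yl the same dimethyl group gives a 29-fold lower number from compound 2 to compound 4 (1.46 log units; beyond the scatter) and so it is compound 2 that stands apart from the other two amides. Nothing measured here explains this result. Still open, as far as these compounds go, is how a single methyl at either ring carbon of the dimethyl pattern would read, and whether a tert-butyl group on the imidazole or an amine in its place would hold such low numbers.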